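Shifting the Hydroxyl on a Shared Core

The source may report more compounds than this note shows. Statements on the series, on what has been measured and on what is new or still open speak of the compounds shown alone.

Among the measured compounds shown here, compound 2 `Oc1cccc(-c2cc(-c3ccc(OC(F)(F)F)cc3)cc(-c3ccccc3O)n2)c1` is the only compound here with a numbered result: in a functional assay on T47D cells (Homo sapiens) for inhibition (on this read-out higher numbers stand for weaker inhibition and lower numbers for stronger inhibition), compound 2 gives 7710 nM. Compound 1 `Oc1ccc(-c2cc(-c3ccc(F)cc3)cc(-c3ccccc3O)n2)cc1` sits at the limit of > 50000 nM in this assay, at which 1 of the 2 values shown sits; in this assay compound 1 gives > 50000 nM, a limit of the assay rather than a number. Compound 3 `Oc1ccc(-c2cc(-c3ccc(OC(F)(F)F)cc3)cc(-c3ccccc3O)n2)cc1` is not yet measured; relative to compound 2 it carries 4-hydroxyphenyl in place of 3-hydroxyphenyl on an aromatic carbon. For the measured compounds named here, no measured pair isolates this change. Compound 1 also bears a 4-hydroxyphenyl group and reaches only the limit. Compound 3 is therefore expected to inhibit more weakly, a step of a 3.2-fold higher number from compound 2 to compound 3 (0.51 log units; beyond the scatter), with an estimate of 25000 nM and a range of 8000 nM to 80000 nM.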

Compound 3, half-maximal inhibitory concentration: > 50000 nM
Compound 3 gave a limit, no number; the forecaster's own chance of this, stated with the estimate: 45%; at least 2.0-fold (0.30 log units) between middle value and limit.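

Among the compounds shown here, with the trifluoromethoxy group held constant, 4-hydroxyphenyl in place of 3-hydroxyphenyl next to the ring nitrogen gives an at least 6.4-fold higher number from compound 2 to compound 3 (0.81 log units; beyond the scatter) in this assay, so the read-out at this position depends on where the hydroxyl sits, which no earlier pair could show. The step from compound 1 to compound 3 cannot be read, as both values are limits of the assay. Compound 2 alone gives a number here: the limit of > 50000 nM in this assay, at which 2 of the 3 values shown sit.

Still open, on these data alone, is how an amine or a carboxylic acid would read in place of the hydroxyl on this ring. Also open, as far as these compounds go, is whether fluoro in place of trifluoromethoxy on compound 2 would keep a number at all.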